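The source may report more compounds than this note shows. Statements on the series, on what has been measured and on what is new or still open speak of the compounds shown alone.

Measured compounds:
- compound 1, `ClCc1ccccc1Cn1cnc2c(Cl)nc(Cl)nc21`: 2950 nM
- compound 2, `ClCc1cccc(Cn2cnc3ncnc(Cl)c32)c1`: 20000 nM
- compound 3, `ClCc1cccc(Cn2cnc3c(Cl)nc(Cl)nc32)c1`: 20400 nM

In a functional assay on OVCAR-5 cells (Homo sapiens) for cytotoxicity, read by sulforhodamine B assay, with a stated time of 48 h (a lower number here means a stronger inhibitor of growth, a higher number a weaker inhibitor of growth), compound 1 gives the lowest of the three numbers. Compound 2 and compound 3 both sit well above it, and their own two values lie close to one another, so among these three compound 1 stands alone at the strong end. Within the data shown here, no pair of the measured compounds differs in just one place, so nothing is yet known about how a single change on this core moves the read-out.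

Compound 4, `Nc1nc(Cl)c2ncn(Cc3ccccc3CCl)c2n1`, is the next compound, not yet measured in this assay. It differs from compound 1 by amino in place of chloro on an aromatic carbon, on the aromatic carbon between two ring nitrogen atoms of the shared core. Among the measured compounds shown here, with no single-point step available for comparison, the direction cannot be read from data. A modest move toward a higher number, of a size somewhat beyond the scatter, is expected, because compound 1 at 2950 nM already holds the strongest position seen. Compound 4 is therefore estimated at 6000 nM, within 1500 nM to 25000 nM. The expected step is a 2.0-fold higher number from compound 1 to compound 4 (0.31 log units; beyond the scatter).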

Compound 4, concentration for total growth inhibition: 39800 nM
Compound 4: the middle estimate sits 6.6-fold (0.82 log units) below what was measured; measured number above the stated range.
By their numbers in this assay, from the lowest: compound 1; then compounds 2, 3 and 4 (each within the scatter of the next).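

In this assay, among these compounds, the first step between compounds differing in one place is large: amino in place of chloro on the aromatic carbon between two ring nitrogen atoms gives a 13-fold higher number from compound 1 to compound 4 (1.13 log units; beyond the scatter) on the shared core. This position is therefore not indifferent to its substituent, since the rest of compound 1 stays the same and the chloro group goes with much stronger growth inhibition than the amino group. Nothing measured here accounts for the size of this step.

Chloro and amino are the only two groups compared at this position, so it remains open whether a methoxy or a dimethylamino group there would read closer to compound 1 or to compound 4. On these data alone, it is also open whether the same change would have an effect of similar size on compound 3, where the chloromethyl group sits elsewhere on the benzyl ring.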